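From isobutyl to benzyl on compound 3

This account rests on a few compounds, and the source may have more. Where it says the series, first, only, none or still open, it means among the compounds named here.

Measured in a functional assay on B16 cells (Mus musculus) for inhibition (on this read-out higher numbers stand for weaker inhibition and lower numbers for stronger inhibition), so far
Compound 1 `CC(C)CN(CC(=O)N(CC(C)C)NC(=O)OCc1ccccc1)NC(=O)CBr` gives 1300 nM
Compound 2 `CC(C)CN(CC(=O)N(CC(C)C)NC(=O)OCc1ccccc1)NC(=O)CNNC(=O)CBr` gives 2500 nM
Compound 3 `CC(C)CN(CC(=O)N(CC(C)C)NC(=O)OCc1ccccc1)/N=C/c1ccccc1B(O)O` gives 26300 nM

Compound 3 has the highest number of the three, which makes it the weakest inhibitor here. The steps of a 20-fold higher number from compound 1 to compound 3 (1.31 log units; beyond the scatter) and an 11-fold higher number from compound 2 to compound 3 (1.02 log units; beyond the scatter) both lie beyond the scatter.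

Compound 4 `CC(C)CN(CC(=O)N(Cc1ccccc1)NC(=O)OCc1ccccc1)/N=C/c1ccccc1B(O)O` has not been measured yet. For the measured compounds named here, its one structural change is phenyl in place of isopropyl on a saturated chain carbon bound to an amide-type nitrogen and, cut one bond further out, this reads isobutyl to benzyl.

Going by the values given here, no measured step touches this place. The two large steps above replaced the group on an amine nitrogen. The step of a 1.9-fold higher number from compound 1 to compound 2 (0.28 log units; within the scatter) stayed within the scatter and changed a saturated chain carbon bound to a carbonyl carbon. With no direct evidence, no shift beyond the scatter is expected in this assay in either direction, though the range must stay wide. The expected 1.2-fold lower number from compound 3 to compound 4 (0.08 log units; within the scatter) stays within the scatter. The estimate for compound 4 is 22000 nM with 7000 nM to 70000 nM as its expected range.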

Compound 4, half-maximal inhibitory concentration: 33500 nM
Compound 4: middle estimate off by 1.5-fold (0.18 log units), on the low side; measured number inside the range.
By their numbers in this assay, from the lowest: compounds 1 and 2 (each within the scatter of the next); then compounds 3 and 4 (each within the scatter of the next).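

Phenyl in place of isopropyl, on a saturated chain carbon bound to an amide-type nitrogen, gives in this assay a 1.3-fold higher number from compound 3 to compound 4 (0.11 log units; within the scatter) and so stays inside the normal spread of repeat measurements. For the compounds shown here, this is the first reading at this place, and it shows that here, on the core of compound 3, isobutyl and benzyl cannot be told apart, whereas changing the group on the amine nitrogen gave a 20-fold higher number from compound 1 to compound 3 (1.31 log units; beyond the scatter) in the same assay. No measurement offers an explanation for this result.

The pair says nothing about whether benzyl would behave the same way on the core of compound 1, where the number is much lower. Also open, going by these compounds, is whether an amine, a carboxylic acid or a longer chain at this place would move the number beyond the scatter.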